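The source may report more compounds than this note shows. Statements on the series, on what has been measured and on what is new or still open speak of the compounds shown alone.

In a functional assay on HO8910 cells (Homo sapiens) for inhibition, read by MTT assay, with a stated time of 24 h, tested at 100 ug/mL (a higher number here means more inhibition of growth at the concentration tested, a lower number less inhibition of growth), two compounds that share one core have been measured so far. Compound 1 `O=C(CCCCC(S)CCS)Nc1ccccc1` gives 13.7%. Compound 2 `O=C(CCCCC(S)CCS)Nc1ccccn1` gives 14.2%, which places it level with compound 1 within the usual scatter, so neither stands apart.

The next compound is compound 3 `O=C(CCCCC(S)CCS)Nc1ccc(Br)cn1`, which keeps all of compound 2 except for one change on the ring: bromo in place of hydrogen on an aromatic carbon.

For the measured compounds named here, only one measured step is available as a guide, and it involves a different change. With pyridin-2-yl in place of phenyl on an amide-type nitrogen, the step is a number 0.5 percentage points higher from compound 1 to compound 2 (within the scatter). This shows that one swap in this part of the molecule left the number within the scatter. Going by the values given here, no measured compound carries a bromo group, so the data give no direct evidence for this change, and no step beyond the scatter can be predicted in either direction.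

The estimated step is a number 0.8 percentage points higher from compound 2 to compound 3 (within the scatter). For compound 3, the expected value is 15%, with an estimated range from 7% to 27%.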

Compound 3, percent growth inhibition at one concentration: 56.8%
Compound 3: middle estimate off by 41.8 percentage points, on the low side; the whole stated range lies below it.
By their numbers in this assay, from the lowest: compounds 1 and 2 (each within the scatter of the next); then compound 3.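

In this assay, the aromatic carbon two atoms from the ring nitrogen, para to a large group, proves to be a sensitive place: bromo in place of hydrogen there gives a number 42.6 percentage points higher from compound 2 to compound 3 (beyond the scatter), a change of a single heavy atom. For the compounds shown here, the only earlier step, pyridin-2-yl in place of phenyl on the amide nitrogen, gave a number 0.5 percentage points higher from compound 1 to compound 2 (within the scatter), so compound 1 and compound 2 alone offered no sign that this part of the molecule could move growth inhibition so strongly. Nothing available bears on why adding this one bromine atom has such a large effect.

On these data alone, whether the rise belongs to bromo specifically or would also come with another group at this position remains open; a chloro, a methyl, a methoxy, an amine or a carboxylic acid placed on the same carbon would help to separate these possibilities. As far as these compounds go, it also remains open whether bromo would produce a similar rise on the phenyl ring of compound 1, or at another carbon of the ring in compound 2.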